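Trifluoromethoxy in place of phenyl on compound 2

This account rests on a few compounds, and the source may have more. Where it says the series, first, only, none or still open, it means among the compounds named here.

In an ADME assay on HCT-116 cells (Homo sapiens) for cytotoxicity, read by CellTiter-Glo, with a stated time of 72 h (a higher number here means a weaker inhibitor, a lower number a stronger inhibitor), compound 1 `Cc1cc(C)c(S(=O)(=O)N2CCN(C3CN4CCC3CC4)CC2)c(C)c1` gives > 5000 nM as its result, a limit of the assay and not a number. In this assay compound 2 `CC1CCN(C2CCN(S(=O)(=O)c3ccc(-c4ccccc4)cc3)CC2)CC1` gives > 5000 nM as its result, so it stands only at a limit. In this assay compound 3 `CC1CCN(C2CCN(S(=O)(=O)c3ccc(F)cc3F)CC2)CC1` gives > 5000 nM as a limit too. Within the data shown here, the set therefore shows the limit of > 5000 nM in this assay, at which 3 of the 3 values shown sit, and offers no step between measured compounds.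

Compound 4 `CC1CCN(C2CCN(S(=O)(=O)c3ccc(OC(F)(F)F)cc3)CC2)CC1` carries trifluoromethoxy in place of phenyl on an aromatic carbon of compound 2, para to a large group: trifluoromethoxy in place of phenyl on an aromatic carbon is the whole change.

The estimated step that the limit leaves unreadable from compound 2 to compound 4 is expected to stay within the usual scatter, with no direction expected. This expectation rests on compound 2 with its limit of > 5000 nM and on nothing firmer.

Compound 4 is estimated at 6000 nM with an expected range of 2500 nM to 15000 nM in this assay and is expected to stand only at a limit.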

Compound 4, half-maximal inhibitory concentration: > 5000 nM
Compound 4 was reported as a limit; the forecaster's own chance of this, stated with the estimate: 85%; the middle value lies beyond the limit too.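

In this assay no step can be read between compound 2 and compound 4, because both results are limits of the assay and not numbers: the limit of > 5000 nM in this assay, at which 4 of the 4 values shown sit. The compounds shown leave open how far any of them lies past that limit, and so whether trifluoromethoxy in place of phenyl alters the result at all.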